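A Second Methoxy on the Sulfonyl Arene

The compounds below may be only part of what the source reports. "The series", "measured", "known", "first", "only" and "open" are said of these compounds alone.

Among the three compounds measured in a functional assay on HCT-116 cells (Homo sapiens) for antiproliferative activity, read by MTT assay, with a stated time of 72 h (a higher number here means a weaker inhibitor, a lower number a stronger inhibitor), compound 3 `COc1ccc(S(=O)(=O)N(C)c2ccc3[nH]c(-c4n[nH]c5ccccc45)cc3n2)cc1` gives the highest number, 22400 nM. Compound 1 `CN(c1ccc2[nH]c(-c3n[nH]c4ccccc34)cc2n1)S(=O)(=O)c1ccccc1` gives 6740 nM, and compound 2 `CN(c1ccc2[nH]c(-c3n[nH]c4ccccc34)cc2n1)S(=O)(=O)c1ccc(Cl)cc1` gives 5980 nM. The change now considered is 2,5-dimethoxyphenyl in place of 4-methoxyphenyl on a sulfonyl sulfur, which yields compound 4 `COc1ccc(OC)c(S(=O)(=O)N(C)c2ccc3[nH]c(-c4n[nH]c5ccccc45)cc3n2)c1`. For the measured compounds named here, the steps that bear on it are a 3.3-fold higher number from compound 1 to compound 3 (0.52 log units; beyond the scatter) and a 3.7-fold higher number from compound 2 to compound 3 (0.57 log units; beyond the scatter), both modest and both beyond the scatter, whereas a 1.1-fold lower number from compound 1 to compound 2 (0.05 log units; within the scatter) stayed within it. Going by the values given here, a single methoxy on the sulfonyl arene thus raised the number; no measured pair shows what a second methoxy does. The expected step is a 1.3-fold higher number from compound 3 to compound 4 (0.10 log units; within the scatter), a modest rise or none beyond the scatter. Compound 4 is therefore estimated at 28000 nM, with a range from 11000 nM to 70000 nM.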

Compound 4, half-maximal inhibitory concentration: 8400 nM
Compound 4: the middle estimate sits 3.3-fold (0.52 log units) above what was measured; measured number outside the range, below it.
By their numbers in this assay, from the lowest: compounds 2, 1 and 4 (each within the scatter of the next); then compound 3.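

In this assay, 2,5-dimethoxyphenyl in place of 4-methoxyphenyl on the sulfonyl sulfur gives a 2.7-fold lower number from compound 3 to compound 4 (0.43 log units; beyond the scatter), so a methoxy-bearing arene at this position need not carry the rise seen with 4-methoxyphenyl. The other two steps, a 1.2-fold higher number from compound 1 to compound 4 (0.10 log units; within the scatter) and a 1.4-fold higher number from compound 2 to compound 4 (0.15 log units; within the scatter), stay within the scatter, which places 2,5-dimethoxyphenyl level with both phenyl and 4-chlorophenyl. No supporting measurement accounts for this result. The compounds shown leave open whether the change depends on both methoxy groups together. They also leave open whether an amine or a carboxylic acid on this arene would move the number beyond that level.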